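Halogen in place of nitro on the anilino ring

The source may report more compounds than this note shows. Statements on the series, on what has been measured and on what is new or still open speak of the compounds shown alone.

Compound 1, `CCOc1ccccc1Nc1nc(SCc2ccc(C(F)(F)F)cc2)nc2ccccc12`, gives in a functional assay on MGC-803 cells (Homo sapiens) for cytotoxicity, read by MTT assay, with a stated time of 72 h (a higher number here means a weaker inhibitor, a lower number a stronger inhibitor), a value that is a limit of the assay, > 50000 nM.
Compound 2, `FC(F)(F)c1ccc(CSc2nc(Nc3cccc(Br)c3)c3ccccc3n2)cc1`, gives in this assay 23700 nM.
Compound 3, `O=[N+]([O-])c1cccc(Nc2nc(SCc3ccc(C(F)(F)F)cc3)nc3ccccc23)c1`, gives in this assay a value that is again a limit of the assay, > 50000 nM.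

Compound 3 thus stands at the limit, (the limit of > 50000 nM in this assay, at which 2 of the 3 values shown sit), and only a bound is known for it. Compound 4 is `FC(F)(F)c1ccc(CSc2nc(Nc3ccc(Cl)cc3)c3ccccc3n2)cc1`. The change from compound 3 is 4-chlorophenyl in place of 3-nitrophenyl on a nitrogen on an aromatic ring. Going by the values given here, two measured steps touch the same position. The move from bromo to nitro gave an at least 2.1-fold higher number from compound 2 to compound 3 (0.32 log units; beyond the scatter), and the move from 2-ethoxyphenyl to 3-bromophenyl gave an at least 2.1-fold lower number from compound 1 to compound 2 (0.32 log units; beyond the scatter), so of the three anilino groups shown only the halogen-bearing one has a value inside the range of this assay. Because the step of an at least 2.1-fold higher number from compound 2 to compound 3 (0.32 log units; beyond the scatter) runs from a number to a limit, replacing nitro with a halogen is expected to run the other way, bringing compound 4 back from the limit toward the value of compound 2. The expected step is an at least 2.0-fold lower number from compound 3 to compound 4 (0.30 log units; that floor lies within the scatter). Compound 4 is therefore estimated at 25000 nM in this assay, within a range from 8000 nM to 50000 nM, with a real chance that the assay again reports only a limit.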

Compound 4, half-maximal inhibitory concentration: 16800 nM
The estimate for compound 4 lay 1.5-fold (0.17 log units) above the measured number; the range from low to high includes it.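

In this assay, 4-chlorophenyl in place of 3-nitrophenyl gives an at least 2.9-fold lower number from compound 3 to compound 4 (0.47 log units; beyond the scatter) and 4-chlorophenyl in place of 2-ethoxyphenyl gives an at least 2.9-fold lower number from compound 1 to compound 4 (0.47 log units; beyond the scatter) on the same nitrogen, so a second halogen-bearing anilino group now has a number inside the range of the assay, where before only the bromo compound had one. Set against that bromo compound, the change gives a 1.4-fold lower number from compound 2 to compound 4 (0.15 log units; within the scatter) and the 3-bromophenyl and 4-chlorophenyl groups cannot be told apart here, although both the halogen and its place on the ring differ between them. Among the four, compound 1 and compound 3 are the two that remain at a limit of the assay: the limit of > 50000 nM in this assay, at which 2 of the 4 values shown sit.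

The compounds shown hold no bromo and chloro pair at the same place on the ring, so whether the number follows the halogen itself or its placing stays open. Going by these compounds, how an amine, a carboxylic acid or a methoxy group on the anilino ring would read in this assay also stays open, as does whether any group at this position would give a number well away from those of the two halogen compounds.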